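The compounds below may be only part of what the source reports. "The series", "measured", "known", "first", "only" and "open" are said of these compounds alone.

Measured in an ADME assay on cells (Homo sapiens) for cytotoxicity, read by polymerase chain reaction, with a stated time of 3 days; a higher number here means that more compound is tolerated, a lower number that less compound is tolerated:
compound 1 `Cc1nc(N)nc(N[C@@H]2C[C@H](CO)[C@@H](O)[C@H]2O)c1-c1nc2cnccc2s1`: 25000 nM
compound 2 `Cc1nc(Nc2ccccc2)nc(N[C@@H]2C[C@H](CO)[C@@H](O)[C@H]2O)c1-c1nc2cnccc2s1`: 25000 nM
compound 3 `Cc1nc(NCc2c(F)cccc2F)nc(N[C@@H]2C[C@H](CO)[C@@H](O)[C@H]2O)c1-c1nc2cnccc2s1`: 4000 nM

Compound 3 stands lowest of the three, and the other two show no difference at the digits given. Compound 4 `Cc1nc(N[C@@H](C)c2ccccc2)nc(N[C@@H]2C[C@H](CO)[C@@H](O)[C@H]2O)c1-c1nc2cnccc2s1` has not yet been measured. It carries 1-phenylethyl in place of 2,6-difluorobenzyl on a nitrogen on an aromatic ring.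

For the measured compounds named here, three measured steps bear on this change. Phenyl in place of hydrogen at that nitrogen gave no change at the digits printed from compound 1 to compound 2 (within the scatter). 2,6-Difluorobenzyl in place of hydrogen gave a 6.3-fold lower number from compound 1 to compound 3 (0.80 log units; beyond the scatter), and 2,6-difluorobenzyl in place of phenyl gave a 6.3-fold lower number from compound 2 to compound 3 (0.80 log units; beyond the scatter). Going by the values given here, no measured compound carries 1-phenylethyl, so the data do not show how much of that modest drop remains once 2,6-difluorobenzyl leaves. Part of it is expected to be recovered in this assay, though not all. The expected step is a 2.3-fold higher number from compound 3 to compound 4 (0.35 log units; beyond the scatter), a modest rise. The estimate for compound 4 is 9000 nM, with an expected range of 3000 nM to 25000 nM.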

Compound 4, half-maximal cytotoxic concentration: 25000 nM
Estimate against measurement, compound 4: 2.8-fold (0.44 log units) below, within the range that was stated.
By their numbers in this assay, from the lowest: compound 3; then compounds 1, 2 and 4 (each within the scatter of the next).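

In this assay, the lower number seen with 2,6-difluorobenzyl does not extend to 1-phenylethyl on this nitrogen, with a 6.3-fold higher number from compound 3 to compound 4 (0.80 log units; beyond the scatter) for this change. Set against the hydrogen and phenyl compounds, 1-phenylethyl shows no change at the digits printed from compound 1 to compound 4 (within the scatter) and no change at the digits printed from compound 2 to compound 4 (within the scatter) in turn, so compound 3 alone stands apart among the four, and a carbon-linked phenyl ring on this nitrogen is not enough by itself to lower the number. Nothing at hand accounts for the difference between the two groups.

The compounds shown leave open whether the lower number of compound 3 goes with its two fluorines or with the absence of the methyl of 1-phenylethyl, a question that unsubstituted benzyl on this nitrogen would address. They also leave open how the opposite stereocentre of 1-phenylethyl would read here.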